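A Further Methoxy Group and Its Expected Effect

The source may hold more compounds than are shown below. What is called first, only, known or untested is meant among the compounds shown, and "the series" means these compounds.

Compound 1 `Cn1cc(-c2nc3ccccc3n2C(=O)c2ccccc2)c2ccccc21` was examined in a functional assay on A549 cells (Homo sapiens) for inhibition, read by MTT assay, with a stated time of 24 h (on this read-out higher numbers stand for weaker inhibition of growth and lower numbers for stronger inhibition of growth), where compound 1 gives 19600 nM. Compound 2 `COc1ccc2c(c1)c(-c1nc3ccccc3n1C(=O)c1ccccc1)cn2C` differs from it by methoxy in place of hydrogen on an aromatic carbon, and in this assay compound 2 gives 16700 nM. That change produced a 1.2-fold lower number from compound 1 to compound 2 (0.07 log units; within the scatter). Compound 3 `COc1ccc(C(=O)n2c(-c3cn(C)c4ccc(Br)cc34)nc3ccccc32)cc1OC` stands on a different core; the difference between the two cores is not broken down here. In this assay compound 3 gives 3400 nM, the lowest of the three numbers and beyond the scatter from both others.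

Compound 4 `COc1cc(C(=O)n2c(-c3cn(C)c4ccc(Br)cc34)nc3ccccc32)cc(OC)c1OC` differs from compound 3 by methoxy in place of hydrogen on an aromatic carbon. This is the same kind of change as that from compound 1 to compound 2, but the surroundings differ: in compound 4 the site is ortho to a methoxy group, meta to a large group and meta to a methoxy group, whereas in compound 2 it is part of a fused or bridged system of two rings, meta to a fused ring and para to a fused ring. Because the earlier step was a 1.2-fold lower number from compound 1 to compound 2 (0.07 log units; within the scatter), the expected step is a 1.1-fold lower number from compound 3 to compound 4 (0.05 log units; within the scatter). In this assay compound 4 is thus estimated at 3000 nM, within 1200 nM to 8000 nM.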

Compound 4, concentration for 50% growth inhibition: 3000 nM
Compound 4: middle estimate and measured number agree at the digits printed, and the stated range covers the measured number.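

In this assay the added methoxy group gave a 1.1-fold lower number from compound 3 to compound 4 (0.05 log units; within the scatter), so the two compounds cannot be told apart on this read-out. Set beside the earlier case, the change looks the same on both cores, even though the surroundings of the new methoxy group differ: the same change on two cores in this assay, a 1.2-fold lower number (0.07 log units; within the scatter) from compound 1 to compound 2 and a 1.1-fold lower number (0.05 log units; within the scatter) from compound 3 to compound 4, 1.0-fold (0.02 log units) apart, within the scatter of two such steps. This shows that the change made no readable difference on either core, but it does not show that a step of real size would carry over from one core to another, and two pairs of compounds make no rule for the series.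

The compounds shown leave open whether a different group at the site ortho to a methoxy group, such as an amine, a hydroxyl group or a longer chain, would shift the number beyond the scatter. They also leave open whether the methoxy change would read the same way on other cores or in other cell lines.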